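This account rests on a few compounds, and the source may have more. Where it says the series, first, only, none or still open, it means among the compounds named here.

In a functional assay on U-87MG ATCC cells for antiproliferative activity against U-87 MG (Homo sapiens), read by MTT assay, with a stated time of 48 h, tested at 5 uM (on this read-out lower numbers stand for a stronger effect and higher numbers for a weaker effect at the one concentration tested), compound 1 `COc1ccc(-c2nc(SCC(=O)c3sc(-c4ccccc4)nc3C)nc(N)c2C#N)cc1` gives 68.8% and compound 2 `COc1ccc(-c2nc(C)c(C(=O)CSc3nc(N)c(C#N)c(-c4ccc(Cl)cc4)n3)s2)cc1` gives 51.4%. Compound 3 `COc1ccc(-c2nc(C)c(C(=O)CSc3nc(-c4ccc(Cl)cc4)c(C#N)c(=O)[nH]3)s2)cc1` gives 102% in this assay, the highest of the three numbers, which on this read-out means the weakest effect on cell growth; compound 1 stands nearest to it and compound 2 furthest, and both gaps lie beyond the usual scatter of repeated measurements. Within the data shown here, none of the three measured compounds differs from another in a single place, so no single structural step has yet been measured. Compound 4 `COc1ccc(-c2nc(C)c(C(=O)CSc3nc(-c4cccc(OC)c4)c(C#N)c(=O)[nH]3)s2)cc1` differs from compound 3 in one place: 3-methoxyphenyl in place of 4-chlorophenyl on an aromatic carbon. Among the measured compounds shown here, nothing among the measured compounds shows what this change does on its own, so the expected step in this assay is a number 8 percentage points lower from compound 3 to compound 4 (within the scatter), a small move downward that may not exceed the scatter. Compound 4 is therefore estimated at 94%, with an expected range from 74% to 110%.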

Compound 4, a percentage reported as activity, at one concentration (the size of the read-out at that concentration, not a potency): 71.3%
Compound 4: the middle estimate sits 22.7 percentage points above what was measured; measured number below the stated range.
By their numbers in this assay, from the lowest: compound 2; then compounds 1 and 4 (each within the scatter of the next); then compound 3.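

On the aromatic carbon next to the ring nitrogen, replacing 4-chlorophenyl with 3-methoxyphenyl gives, in this assay, a number 30.7 percentage points lower from compound 3 to compound 4 (beyond the scatter). Among these compounds, this is the first change in a single place to be read here, and it shows that the aryl group at this position is not a silent part of the molecule: changing it alone moves compound 3, which showed the weakest effect, to a clearly stronger effect in compound 4. Nothing available explains why the number moved.

Going by these compounds, the change alters both the substituent and its place on the phenyl ring, so it remains open which of the two carries the step, a question a 3-chlorophenyl group at this position would bear on. Also open, on these data alone, is whether a 3-aminophenyl group, with an amine in place of the methoxy, would move the number the same way.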